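Methyl added to compound 1: working notes

The source may hold more compounds than are shown below. What is called first, only, known or untested is meant among the compounds shown, and "the series" means these compounds.

In a functional assay on cells (Mast cell, Rattus norvegicus, strain Wistar) for activation, read by fluorescence, with a stated time of 15 min (on this read-out higher numbers stand for an effect only at larger amounts of compound and lower numbers for an effect already at smaller amounts), compound 1 (`CCCCCCCCCCCCCCCCCC(=O)OCCCOP(=O)(O)OC[C@H](N)C(=O)O`) gives 500 nM and compound 2 (`CCCCCCCCCCCCCCCCCC(=O)OC[C@H](O)COP(=O)(O)OC[C@H](N)C(=O)O`) gives 1000 nM. These values lie within the scatter of each other, so compound 1 has no distinct rank. Compound 3 (`CCCCCCCCCCCCCCCCCC(=O)OCCCOP(=O)(O)O[C@H](C)[C@H](N)C(=O)O`) carries methyl in place of hydrogen on a saturated chain carbon bound to an oxygen and a saturated chain carbon. Among the measured compounds shown here, the only measured step, a 2.0-fold higher number from compound 1 to compound 2 (0.30 log units; within the scatter), is a hydroxy change on a different carbon, and no measured step covers this methyl. It gives weak guidance, so no step beyond the scatter is expected. The estimated step is a 1.7-fold lower number from compound 1 to compound 3 (0.22 log units; within the scatter). For compound 3 the expected value is 300 nM, with an estimated range of 50 nM to 1500 nM.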

Compound 3, half-maximal effective concentration: 100 nM
Compound 3: the middle estimate sits 3.0-fold (0.48 log units) above what was measured; the range from low to high includes it.
By their numbers in this assay, from the lowest: compound 3; then compounds 1 and 2 (each within the scatter of the next).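

Methyl in place of hydrogen on a saturated chain carbon bound to an oxygen and a saturated chain carbon gives a 5.0-fold lower number from compound 1 to compound 3 (0.70 log units; beyond the scatter) in this assay. Among the compounds shown here, this is the first step beyond the scatter, so the read-out responds to a change at this position, which the hydroxy step did not show. Nothing shown bears on the cause of this step.

As far as these compounds go, whether ethyl or a longer chain on this same carbon keeps the lower number remains open. Also open, from the compounds shown here alone, is whether methyl gives a similar step alongside the hydroxy of compound 2.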